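Changing one aryl group on a sulfonamide nitrogen

The source may hold more compounds than are shown below. What is called first, only, known or untested is meant among the compounds shown, and "the series" means these compounds.

In a functional assay on MCF7 cells (Homo sapiens) for antiproliferative activity, read by MTT assay, with a stated time of 72 h (a higher number here means a weaker inhibitor, a lower number a stronger inhibitor), compound 1 `CN(c1cccc2ccccc12)S(=O)(=O)C1CC2OC1C(c1ccc(NC(=O)CCCCCCC(=O)O)cc1)=C2c1ccc(O)cc1` gives 14000 nM, and compound 2 `CCN(c1cccc(C)c1)S(=O)(=O)C1CC2OC1C(c1ccc(NC(=O)CCCCCCC(=O)O)cc1)=C2c1ccc(O)cc1` gives 31800 nM. Compound 2 therefore has the higher of the two numbers, which makes it the weaker inhibitor of this pair.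

Compound 3 `CCN(c1ccc(Cl)cc1)S(=O)(=O)C1CC2OC1C(c1ccc(NC(=O)CCCCCCC(=O)O)cc1)=C2c1ccc(O)cc1` keeps the ethyl group of compound 2 but has 4-chlorophenyl in place of 3-methylphenyl on a sulfonamide nitrogen.

Among the compounds with values here, only one measured step bears on this change: a 2.3-fold higher number from compound 1 to compound 2 (0.36 log units; beyond the scatter). That modest step replaced methyl(naphthalen-1-yl)amino with ethyl(3-methylphenyl)amino, so it altered both groups on the nitrogen. The new change alters only one of them, and neither measured compound carries a chlorine, so the data give no firm direction. Within the data shown here, a smaller step than that one therefore seems likely in this assay, with a slight lean towards a lower number, since compound 2 at 31800 nM is the higher of only two values.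

The expected change is a 1.3-fold lower number from compound 2 to compound 3 (0.10 log units; within the scatter), which would not go beyond the usual scatter. For compound 3 the estimated value is 25000 nM, with an expected range of 11000 nM to 50000 nM.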

Compound 3, half-maximal inhibitory concentration: 22100 nM
The estimate for compound 3 lay 1.1-fold (0.05 log units) above the measured number; the range from low to high includes it.
By their numbers in this assay, from the lowest: compounds 1, 3 and 2 (each within the scatter of the next, the first and the last beyond it).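

In this assay, exchanging only the aryl group on the sulfonamide nitrogen while keeping the ethyl group gives a 1.4-fold lower number from compound 2 to compound 3 (0.16 log units; within the scatter) and so does not separate 4-chlorophenyl from 3-methylphenyl, although one ring carries a chlorine and the other a methyl group. Replacing the methyl(naphthalen-1-yl)amino group gives a 1.6-fold higher number from compound 1 to compound 3 (0.20 log units; within the scatter) when (4-chlorophenyl)(ethyl)amino enters, against a 2.3-fold higher number from compound 1 to compound 2 (0.36 log units; beyond the scatter) when ethyl(3-methylphenyl)amino enters, so leaving the naphthalene behind does not always produce a step beyond the scatter. No measured property of these groups accompanies these numbers, so nothing here accounts for them.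

The compounds shown leave open whether a group of a different kind on this nitrogen, such as a pyridine ring, a benzyl group or a cyclohexyl ring, would give a clearer step than these aryl groups do. They also leave open what the ethyl group contributes, a question that a compound with a propyl chain or a plain hydrogen in its place, and the same 4-chlorophenyl ring, could begin to address.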